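Cyano for trifluoromethyl on the anilide of compound 2

This account rests on a few compounds, and the source may have more. Where it says the series, first, only, none or still open, it means among the compounds named here.

Three compounds of the series have been run in a functional assay on HL-60 cells (Homo sapiens) for cytotoxicity, read by luminescence and CellTiter-Glo, with a stated time of 3 days; a lower number here means a stronger inhibitor, a higher number a weaker inhibitor. Compound 2 `O=C(Nc1ccc(C(F)(F)F)cc1)c1cc(Cl)c(-c2ccccc2)cc1O` gives 490 nM, the lowest of the three numbers shown, though within the scatter of both others. Compound 3 `O=C(Nc1ccc(C(F)(F)F)cc1)c1cc(Cl)ccc1O` gives 510 nM, and compound 1 `N#Cc1cc(Cl)ccc1NC(=O)c1ccc2cccnc2c1O`, built on a different core, gives 790 nM. Within the data shown here, the only step between compounds that differ in a single place is a 1.0-fold higher number from compound 2 to compound 3 (0.02 log units; within the scatter); hydrogen in place of phenyl on an aromatic carbon leaves the number essentially where it was.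

Compound 4 `N#Cc1ccc(NC(=O)c2cc(Cl)c(-c3ccccc3)cc2O)cc1` is not yet measured. It differs from compound 2 in one place: cyano in place of trifluoromethyl on an aromatic carbon The trifluoromethyl leaves and a cyano enters, on an aromatic carbon of a six-membered aromatic ring of carbon only, para to a large group.

Among the measured compounds shown here, no measured step bears directly on this exchange. The step from compound 2 to compound 3 concerns the phenyl, not the anilide substituent, and compound 1 carries its cyano on a different core, so its value cannot be set against compound 2 as a single-place step. For compound 4 in this assay the expectation is therefore no step beyond the scatter, a 1.2-fold higher number from compound 2 to compound 4 (0.09 log units; within the scatter), with a wide range to reflect the missing comparison. Compound 4 is estimated at 600 nM, between 250 nM and 1500 nM.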

Compound 4, half-maximal inhibitory concentration: 520 nM
The estimate for compound 4 lay 1.2-fold (0.06 log units) above the measured number, and the stated range covers the measured number.
By their numbers in this assay, from the lowest: compounds 2, 3, 4 and 1 (each within the scatter of the next).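

In this assay, among these compounds, the exchange of trifluoromethyl for cyano, on an aromatic carbon of a six-membered aromatic ring of carbon only, para to a large group, gives a 1.1-fold higher number from compound 2 to compound 4 (0.03 log units; within the scatter) and is the first single-place reading at this position. Trifluoromethyl, with 4 heavy atoms and no hydrogen-bond acceptor, and cyano, with 2 heavy atoms and 1 hydrogen-bond acceptor, are therefore interchangeable here within the scatter, at least with the phenyl present. The other single-place exchange in the series, a 1.0-fold higher number from compound 2 to compound 3 (0.02 log units; within the scatter), also stays within the scatter, so neither of the two places examined has yet produced a step beyond it, and no measurement of any property of these groups accompanies the result.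

Still open, going by these compounds, is whether a carboxylic acid, an amine or a plain hydrogen at this position would move the number beyond the scatter, since both groups compared here are uncharged and carry no hydrogen-bond donor. Also open is whether cyano reads the same on the shared core with hydrogen in place of phenyl, a pairing that the compounds shown do not cover.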